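Chain Lengthening of a Hydroxamate Series on THP-1 Cells

The source may hold more compounds than are shown below. What is called first, only, known or untested is meant among the compounds shown, and "the series" means these compounds.

Three hydroxamic acids sharing one core have been measured. Compound 1 `Cc1noc(C)c1-c1ccc2c(c1)c(CCc1ccccc1)cn2CCCCCC(=O)NO` has a hydroxycarbamoyl group on a saturated chain carbon, five bonds along the chain from an aromatic nitrogen. In a functional assay on THP-1 cells (Homo sapiens) for inhibition (on this read-out higher numbers stand for weaker inhibition of growth and lower numbers for stronger inhibition of growth), compound 1 gives 15500 nM. Compound 2 `Cc1noc(C)c1-c1ccc2c(c1)c(CCc1ccccc1)cn2CCCCCCC(=O)NO` differs from it by the change ((hydroxycarbamoyl)methyl in place of hydroxycarbamoyl on a saturated chain carbon, five bonds along the chain from an aromatic nitrogen), and in this assay compound 2 gives 15500 nM, so the step of no change at the digits printed from compound 1 to compound 2 (within the scatter) is flat. Compound 3 `Cc1ccc(Cc2cn(CCCCCC(=O)NO)c3ccc(-c4c(C)noc4C)cc23)cc1` carries a different core, the difference being (4-methylphenyl in place of benzyl on a saturated chain carbon bound to an aromatic carbon); in this assay compound 3 gives 15500 nM, and the step of no change at the digits printed from compound 1 to compound 3 (within the scatter) is likewise flat. All three values sit together within the scatter, so none can be ranked against another.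

Compound 4 `Cc1ccc(Cc2cn(CCCCCCC(=O)NO)c3ccc(-c4c(C)noc4C)cc23)cc1` is not yet measured. It differs from compound 3 by (hydroxycarbamoyl)methyl in place of hydroxycarbamoyl on a saturated chain carbon, five bonds along the chain from an aromatic nitrogen, which is the same change as that from compound 1 to compound 2, made at the same place on a different core. Because that earlier step no change at the digits printed from compound 1 to compound 2 (within the scatter) showed no change, the step from compound 3 to compound 4 is expected to be about as small, no change at the digits printed from compound 3 to compound 4 (within the scatter). Within the data shown here, on this basis compound 4 is estimated to give 15500 nM in this assay, within a range from 7000 nM to 35000 nM, resting on the single precedent of compound 1 and compound 2.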

Compound 4, concentration for 50% growth inhibition: 15500 nM
The estimate for compound 4 equals the measured number at the digits printed, within the range that was stated.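

In this assay the lengthening of the chain, (hydroxycarbamoyl)methyl in place of hydroxycarbamoyl, gives no change at the digits printed from compound 3 to compound 4 (within the scatter), and on this reading the change carries from one core to the other: the same change on two cores in this assay, no change at the digits printed (within the scatter) from compound 1 to compound 2 and no change at the digits printed (within the scatter) from compound 3 to compound 4, 1.0-fold (0.00 log units) apart, within the scatter of two such steps. The other change, 4-methylphenyl in place of benzyl, gives no change at the digits printed from compound 2 to compound 4 (within the scatter), and it carries over in the same way: the same change on two cores in this assay, no change at the digits printed (within the scatter) from compound 1 to compound 3 and no change at the digits printed (within the scatter) from compound 2 to compound 4, 1.0-fold (0.00 log units) apart, within the scatter of two such steps. Among these compounds, this shows only that two flat steps agree across these four compounds, with compounds 1, 2 and 3 level with compound 4 at 15500 nM; it does not show that either change would stay flat on any other core, and steps that do not move the value cannot show how a change that does move it would transfer.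

Going by these compounds, whether a longer chain such as 2-(hydroxycarbamoyl)ethyl or 3-(hydroxycarbamoyl)propyl would shift the value in this assay remains open, as does the effect of a carboxylic acid or a primary amide in place of the hydroxycarbamoyl group. Also open, on these data alone, is what a chlorine or a methoxy group in place of the methyl on the 4-methylphenyl group would do, and whether any of these steps would behave the same way on both cores.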